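The compounds below may be only part of what the source reports. "The series", "measured", "known", "first", "only" and "open" are said of these compounds alone.

For the measured compounds named here, compound 1 `COc1cc(C(=O)c2sc(-c3ccc([N+](=O)[O-])cc3)cc2N)cc(OC)c1OC` is one of two compounds measured in a functional assay on L1210 cells (Mus musculus) for antiproliferative activity; on this read-out lower numbers stand for stronger inhibition and higher numbers for weaker inhibition. In this assay compound 1 gives 100 nM, the highest of the two numbers; the nearest is compound 2 `COc1cc(C(=O)c2sc(-c3ccc(C)cc3)cc2N)cc(OC)c1OC`, which gives 18 nM. Compound 3 `COc1cc(C(=O)c2sc(-c3ccc(C(F)(F)F)cc3)cc2N)cc(OC)c1OC` has not yet been measured. It differs from compound 1 by trifluoromethyl in place of nitro on an aromatic carbon, on an aromatic carbon of a six-membered aromatic ring of carbon only, para to a large group.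

Going by the values given here, one measured step bears on this change: a 5.6-fold lower number from compound 1 to compound 2 (0.74 log units; beyond the scatter), where the nitro group was also replaced, there by methyl. On these data alone, that single step points toward a lower number when the nitro group leaves this position, and so a lower number for compound 3 is expected as well, though the trifluoromethyl group is untested here. Compound 3 is estimated at 40 nM, within 12 nM to 130 nM, a step of a 2.5-fold lower number from compound 1 to compound 3 (0.40 log units; beyond the scatter).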

Compound 3, half-maximal inhibitory concentration: 370 nM
The estimate for compound 3 lay 9.3-fold (0.97 log units) below the measured number; measured number above the stated range.
By their numbers in this assay, from the lowest: compound 2; then compound 1; then compound 3.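

In this assay, the loss of nitro from this place does not in itself lower the number: trifluoromethyl gives a 3.7-fold higher number from compound 1 to compound 3 (0.57 log units; beyond the scatter), the opposite direction to a 5.6-fold lower number from compound 1 to compound 2 (0.74 log units; beyond the scatter). The outcome therefore depends on the group that enters, and the two replacements end far apart, with a 21-fold higher number from compound 2 to compound 3 (1.31 log units; beyond the scatter) showing that methyl and trifluoromethyl are not interchangeable here, despite their similar shape on paper. Nothing available explains why the three compounds fall in this order.

Three groups at a single place are too few to define a rule for this position. On these data alone, it remains open whether a methoxy group, an amine or a chlorine atom on an aromatic carbon here would give a number nearer that of compound 2 or that of compound 3.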